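From 3-hydroxyphenyl to tert-butyl: a weak antiproliferative series

The compounds below may be only part of what the source reports. "The series", "measured", "known", "first", "only" and "open" are said of these compounds alone.

Compound 1 `O=C1O[C@H]([C@@H](O)Cn2cc(-c3cccc(O)c3)nn2)C(OCc2ccccc2)=C1OCc1ccccc1`: 39300 nM
Compound 2 `O=C1O/C(=C\Cn2cc(-c3cc(C(F)(F)F)cc(C(F)(F)F)c3)nn2)C(OCc2ccccc2)=C1OCc1ccccc1`: > 100000 nM

Among the measured compounds shown here, in a functional assay on HeLa cells (Homo sapiens) for antiproliferative activity, read by MTT assay, with a stated time of 72 h (a lower number here means a stronger inhibitor, a higher number a weaker inhibitor), compound 1 gives 39300 nM, the only exact number so far. Compound 2 gives > 100000 nM, which is a limit of the assay and not a number. Compound 3 `CC(C)(C)c1cn(C[C@H](O)[C@H]2OC(=O)C(OCc3ccccc3)=C2OCc2ccccc2)nn1` has not yet been measured. It carries tert-butyl in place of the 3-hydroxyphenyl of compound 1, on an aromatic carbon: tert-butyl in place of 3-hydroxyphenyl on an aromatic carbon. For the measured compounds named here, no measured pair shows this change, so the expectation is only tentative. A modest weakening in this assay is expected, an estimated 1.5-fold higher number from compound 1 to compound 3 (0.18 log units; within the scatter). For compound 3, the estimated value is 60000 nM, with an expected range of 20000 nM to 100000 nM.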

Compound 3, half-maximal inhibitory concentration: 18300 nM
Compound 3: the middle estimate sits 3.3-fold (0.52 log units) above what was measured; measured number outside the range, below it.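

In this assay the aromatic carbon of the five-membered ring accepts the loss of the whole 3-hydroxyphenyl group: tert-butyl there gives a 2.1-fold lower number from compound 1 to compound 3 (0.33 log units; beyond the scatter) and the number does not rise. Neither the six-membered aromatic ring nor its hydrogen-bond donor is therefore needed for the weak activity of compound 1. The values shown offer no explanation for this step. From the compounds shown here alone, whether an amine or a longer alkyl chain at this position would lower the number further remains open. So does whether a group as small as methyl would do the same.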